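The compounds below may be only part of what the source reports. "The series", "measured", "known", "first", "only" and "open" are said of these compounds alone.

Compound 1 `COc1cc(-c2nccn2CC(C)C)cc(OC)c1OC`: > 100000 nM
Compound 2 `COc1cc(-c2nccn2-c2ccc3sccc3c2)cc(OC)c1OC`: 3300 nM
Compound 3 `COc1cc(-c2nccn2-c2ccc3[nH]ccc3c2)cc(OC)c1OC`: 4600 nM

All three values come from a functional assay on HCT-15 cells (Homo sapiens) for antiproliferative activity, read by MTT assay, with a stated time of 72 h; on this read-out lower numbers stand for stronger inhibition and higher numbers for weaker inhibition. Compound 1 gives > 100000 nM, which is a limit and not a number. Compound 1 therefore sits at the limit of > 100000 nM in this assay, at which 1 of the 3 values shown sits.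

Compound 4 `COc1cc(-c2nccn2-c2ccc(F)cc2)cc(OC)c1OC` keeps the core of compound 1 and changes one group: 4-fluorophenyl in place of isobutyl on an aromatic nitrogen. Compound 2 gives 3300 nM and compound 3 gives 4600 nM, and both carry an aromatic group on that same nitrogen. On that basis a large step toward stronger inhibition in this assay is expected, not one within the scatter. The expected change is an at least 12-fold lower number from compound 1 to compound 4 (1.09 log units; beyond the scatter). For compound 4 the estimated value is 8000 nM, with an expected range of 2000 nM to 40000 nM.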

Compound 4, half-maximal inhibitory concentration: 68600 nM
Compound 4: the middle estimate sits 8.6-fold (0.93 log units) below what was measured; the measured number lies above the stated range.
By their numbers in this assay, from the lowest: compounds 2 and 3 (each within the scatter of the next); then compound 4. At a limit, above all of these: compound 1.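

In this assay, 4-fluorophenyl in place of isobutyl on the aromatic nitrogen gives an at least 1.4-fold lower number from compound 1 to compound 4 (0.16 log units; that floor lies within the scatter). Compound 4 stands at 68600 nM, while compound 2 gives 3300 nM and compound 3 gives 4600 nM, so an aromatic group on this nitrogen does not alone set the level. The true size of the step stays open because compound 1 carries a limit: the limit of > 100000 nM in this assay, at which 1 of the 4 values shown sits.

Open, on these data alone, is what the fluorine contributes to compound 4. A plain phenyl, or a phenyl bearing a methoxy group or an amine, on the same nitrogen would bear on this.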